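Replacing the dimethylsulfamoyl group: microsomal stability notes

The source may hold more compounds than are shown below. What is called first, only, known or untested is meant among the compounds shown, and "the series" means these compounds.

Measured in an in vitro ADME assay on microsomes from liver (Homo sapiens) for metabolic stability; on this read-out lower numbers stand for a shorter-lived compound and higher numbers for a longer-lived compound:
compound 1 `COc1ccc(-c2cc(-c3ccc(S(=O)(=O)N(C)C)cc3)cnc2N)cn1`, 0.292 h
compound 2 `COc1ccc(-c2cc(-c3ccc(-n4cccn4)cc3)cnc2N)cn1`, 3.38 h
compound 3 `COc1ccc(-c2cc(-c3ccc4cnn(C)c4c3)cnc2N)cn1`, 2.38 h

Compound 1 has the lowest number of the three in this assay; the nearest is compound 3, and the furthest is compound 2, both beyond the scatter. Within the data shown here, the only single-point step among the measured compounds is a 12-fold higher number from compound 1 to compound 2 (1.06 log units; beyond the scatter), a large gain.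

The unmeasured compound 4 `COc1ccc(-c2cc(-c3ccc(C(=O)O)cc3)cnc2N)cn1` differs from compound 1 in one place: carboxy in place of dimethylsulfamoyl on an aromatic carbon. Among the measured compounds shown here, the step from compound 1 to compound 2 is the only one that changes the same position, and it went up strongly; the group entering there was a ring, whereas carboxy brings no ring and a hydrogen-bond donor, so that step is a loose guide at best. Compound 3 changes a different region and adds nothing on the carboxy question. No acid appears among the measured compounds.

Expectation for compound 4 in this assay is therefore a modest rise over compound 1, wide in range, a 3.4-fold higher number from compound 1 to compound 4 (0.53 log units; beyond the scatter). Compound 4 is estimated at 1 h, between 0.3 h and 4 h.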

Compound 4, half-life: > 4.16 h
Compound 4: only a limit was reported; the forecaster's own chance of this, stated with the estimate: 10%; at least 4.1-fold (0.61 log units) between middle value and limit.
By their numbers in this assay, from the lowest: compound 1; then compounds 3 and 2 (each within the scatter of the next). At a limit, above all of these: compound 4.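

In this assay compound 4 is held by a limit of the assay and not by a number: the limit of > 4.16 h in this assay, at which 1 of the 4 values shown sits.

Carboxy on this aromatic carbon, para to a large group, gives an at least 14-fold higher number from compound 1 to compound 4 (1.15 log units; beyond the scatter) and so shows what compound 2 alone could not: the rise on losing dimethylsulfamoyl does not require an entering ring. Set against 1H-pyrazol-1-yl, the same carboxy gives an at least 1.2-fold higher number from compound 2 to compound 4 (0.09 log units; that floor lies within the scatter) and no order between these two groups can be read from that floor.

Whether the gain belongs to carboxy itself or simply to the loss of dimethylsulfamoyl stays open, with only two entering groups shown at this carbon; a primary carboxamide, a methyl ester or a methylsulfonyl group there would separate these two readings. As far as these compounds go, the actual half-life of compound 4 also stays unknown, and with it the size of any gap to compound 2.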